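The compounds below may be only part of what the source reports. "The series", "measured", "known", "first", "only" and "open" are said of these compounds alone.

Compound 1 (`CCC1CCc2c(sc(NC(=O)Nc3ccc(Cl)cc3)c2C(N)=O)C1`) is tested in a functional assay (strain AB) with Danio rerio as the target, read by microscopy, with a stated time of 1 h (on this read-out lower numbers stand for an effect already at smaller amounts and higher numbers for an effect only at larger amounts of compound), where it gives > 25000 nM. That value is a limit of the assay and not a number. Compound 2 (`NC(=O)c1c(NC(=O)Nc2ccc(Cl)cc2)sc2c1CCN(CCCNC(=O)CCc1cccc3ccccc13)C2`) does give a number in this assay, namely 110 nM. On these two results, compound 1 stands at the high end of what has been seen so far, with no exact position of its own.

Compound 3 (`C[N+]1(C2CCc3c(sc(NC(=O)Nc4ccc(Cl)cc4)c3C(N)=O)C2)CCC1`) keeps the core of compound 1 and alters one group, on a saturated ring carbon: a group of 5 heavy atoms (4 carbon, 1 nitrogen; one four-membered non-aromatic ring with 1 hetero atom) in place of a group of 2 heavy atoms (2 carbon; no ring), on a saturated ring carbon. The ethyl group gives way to a group with a four-membered non-aromatic ring, and the new group carries a net charge of +1.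

Within the data shown here, no measured pair shows what a change of this kind does, so any forecast is loose. Compound 2 reaches 110 nM, so a much lower result is possible. A sizeable step towards lower numbers in this assay is expected, though compound 3 may also stay at the limit. The expected change is an at least 8.3-fold lower number from compound 1 to compound 3 (0.92 log units; beyond the scatter). For compound 3 the estimated value is 3000 nM, with an expected range from 300 nM to 25000 nM.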

Compound 3, half-maximal effective concentration: 3920 nM
Compound 3: middle estimate off by 1.3-fold (0.12 log units), on the low side, and the stated range covers the measured number.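

In this assay, placing the group with a four-membered non-aromatic ring and a net charge of +1 on the saturated ring carbon, in place of the ethyl group, gives an at least 6.3-fold lower number from compound 1 to compound 3 (0.80 log units; beyond the scatter). Among these compounds, this is the first step read at this place, and it shows that a change of group here alone can move the read-out beyond the usual scatter, with no other part of the molecule altered. The full size of the step cannot be read, because compound 1 carries a limit of the assay and not a number: the limit of > 25000 nM in this assay, at which 1 of the 3 values shown sits.

From the compounds shown here alone, a single step changes several things at once, so it remains open whether the ring, the net charge of +1 or simply the larger group accounts for the lower number. Results for a propyl chain, a cyclobutyl ring or a dimethylamino group on this same saturated ring carbon would begin to separate these three features, since each keeps some of them and drops others.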